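Hydrazone series: dimethylamino aryl replacing dimethoxy aryl

The source may hold more compounds than are shown below. What is called first, only, known or untested is meant among the compounds shown, and "the series" means these compounds.

Within the data shown here, compound 1 `COc1ccc(/C=N/Nc2nc3ccccc3nc2Cc2ccccc2)cc1OC` is tested in an assay on isolated protein for inhibition of Amine oxidase [flavin-containing] B (Homo sapiens), read by spectrophotometry (a higher number here means a weaker inhibitor, a lower number a stronger inhibitor), where compound 1 gives 460000 nM, the highest of the two numbers so far. Compound 2 `COc1ccc(/C(C)=N/Nc2nc3ccccc3nc2Cc2ccccc2)cc1` sits nearest, and in this assay compound 2 gives 280000 nM, within the scatter of compound 1. Compound 3 `CN(C)c1ccc(/C=N/Nc2nc3ccccc3nc2Cc2ccccc2)cc1` carries the change (4-(dimethylamino)phenyl in place of 3,4-dimethoxyphenyl on a carbon with a double bond to nitrogen), a 4-(dimethylamino)phenyl in place of 3,4-dimethoxyphenyl on the carbon double-bonded to nitrogen. Among the measured compounds shown here, no measured pair separates this change, so the expected step of a 1.3-fold lower number from compound 1 to compound 3 (0.12 log units; within the scatter) is none beyond the scatter. Compound 3 is expected to give 350000 nM, between 100000 nM and 1200000 nM.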

Compound 3, half-maximal inhibitory concentration: 880000 nM
For compound 3 the middle estimate is 2.5-fold (0.40 log units) below the measured one, within the range that was stated.
By their numbers in this assay, from the lowest: compounds 2, 1 and 3 (each within the scatter of the next, the first and the last beyond it).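

In this assay, the step to 4-(dimethylamino)phenyl in place of 3,4-dimethoxyphenyl on a carbon with a double bond to nitrogen is a 1.9-fold higher number from compound 1 to compound 3 (0.28 log units; within the scatter) and so gives no separable difference between the two aryl groups. Replacing both methoxy groups with one dimethylamino group therefore leaves this pair's readings within the scatter, with compound 3 at 880000 nM in the same high range. Nothing measured here explains the result.

Open, from the compounds shown here alone, is whether a carboxylic acid or a morpholine on the phenyl ring at this position would shift the number beyond the scatter.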